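The source may report more compounds than this note shows. Statements on the series, on what has been measured and on what is new or still open speak of the compounds shown alone.

Two ureas share one core. Compound 1 `Cc1cccc(C)c1NC(=O)Nc1ccncc1` gives in a functional assay on the whole organism with Mus musculus as the target, in the maximal electroshock model, with a stated time of 30 min (on this read-out lower numbers stand for an effect already at smaller amounts and higher numbers for an effect only at larger amounts of compound), a value of 30 mg/kg. Compound 2 `O=C(Nc1ccncc1)Nc1ccccc1Br` gives in this assay a value of 100 mg/kg, the highest of the two numbers; compound 1 stands at a lower number, a gap beyond the scatter. Compound 3 `O=C(Nc1ccncc1)Nc1ccccc1F`, not yet measured, differs from compound 2 by fluoro in place of bromo on an aromatic carbon. Within the data shown here, no comparable pair is measured, so only a modest move is expected, a step of a 1.7-fold lower number from compound 2 to compound 3 (0.22 log units; within the scatter), at or near the edge of the scatter. Compound 3 is therefore estimated at 60 mg/kg, with a range from 30 mg/kg to 150 mg/kg.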

Compound 3, minimum effective dose: 100 mg/kg
The estimate for compound 3 lay 1.7-fold (0.22 log units) below the measured number; the range from low to high includes it.
By their numbers in this assay, from the lowest: compound 1; then compounds 2 and 3 (each within the scatter of the next).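

Fluoro in place of bromo on an aromatic carbon ortho to a large group gives, in this assay, no change at the digits printed from compound 2 to compound 3 (within the scatter). Among these compounds, this is the first pair that differs in one place, and at this position the read-out does not separate the two halogens. No measured property bears on this result, so the data offer no explanation for it.

Compound 1 differs from compounds 2 and 3 in more than one place, so its lower number cannot be tied to any single group. From the compounds shown here alone, how a methyl, a methoxy or an amine would read on this carbon remains open.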